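Lengthening a hydroxylated chain at the assay limit

This account rests on a few compounds, and the source may have more. Where it says the series, first, only, none or still open, it means among the compounds named here.

- compound 1 `CC(=O)C(C)CCCCc1cc(O)c(C)c(=O)o1` gives > 200000 nM
- compound 2 `Cc1c(O)cc(CCCC(C)C)oc1=O` gives > 200000 nM
- compound 3 `Cc1c(O)cc(CCCCC(C)(C)O)oc1=O` gives > 200000 nM

All three compounds were tested in a functional assay on HepG2 cells (Homo sapiens) for cytotoxicity, read by MTT assay (a lower number here means a stronger inhibitor, a higher number a weaker inhibitor), and none returned an exact number. Compound 3 gives > 200000 nM here, which is a limit of the assay and not a number. The picture so far is the limit of > 200000 nM in this assay, at which 3 of the 3 values shown sit, and nothing finer, so compound 3 has no exact place among the others.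

Compound 4 `Cc1c(O)cc(CCCCC(C)[C@H](C)O)oc1=O` alters the end of the chain, counted as 2-hydroxy-1-methylpropyl in place of 1-hydroxy-1-methylethyl on a saturated chain carbon, four bonds along the chain from an aromatic carbon in this change: 2-hydroxy-1-methylpropyl in place of 1-hydroxy-1-methylethyl, on a saturated chain carbon, four bonds along the chain from an aromatic carbon.

Among the measured compounds shown here, the steps that bear on this are a step that the two limits leave unreadable from compound 2 to compound 3 and a step that the two limits leave unreadable from compound 1 to compound 3 and neither has a readable size. For the measured compounds named here, no measured size carries over, and the only guide is that every chain end so far sits at the limit. The expected change is a step that the limit leaves unreadable from compound 3 to compound 4 and nothing beyond the usual scatter. Compound 4 is estimated at 250000 nM with an expected range from 120000 nM to 500000 nM and will most likely report only a limit again.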

Compound 4, half-maximal inhibitory concentration: > 200000 nM
Compound 4: no number, only a limit; the forecaster's own chance of this, stated with the estimate: 85%; the middle value lies beyond the limit too.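

Compound 4 gives > 200000 nM in this assay, and that is a limit of the assay, not a number. The steps to compound 4 from compound 1, compound 2 and compound 3 therefore cannot be read. Left open is how these chain ends compare with one another, with only this to go on: the limit of > 200000 nM in this assay, at which 4 of the 4 values shown sit.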